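One Aryl Ring Swapped on a Shared Core

A few compounds are considered here, and "the series" means these few. Any claim that something is new, unique, unknown or untested is made for them only; others in the source may bear on it.

Measured compounds:
compound 1 `COc1ccc(C(=O)/C=C/c2cccc([N+](=O)[O-])c2)c2c1C=CC(C)(C)O2`: 4090 nM
compound 2 `COc1ccc(C(=O)/C=C/c2ccc(Cl)c(Cl)c2)c2c1C=CC(C)(C)O2`: 7700 nM

In a functional assay on SW-620 cells (Homo sapiens) for antiproliferative activity, read by MTT assay, with a stated time of 24 h (on this read-out higher numbers stand for weaker inhibition and lower numbers for stronger inhibition), compound 1 gives 4090 nM. Within the data shown here, compound 2 gives 7700 nM, the higher of the two numbers, but the only measured step, a 1.9-fold higher number from compound 1 to compound 2 (0.27 log units; within the scatter), lies within the scatter, so the two compounds cannot be ranked against each other.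

Compound 3 `COc1ccc(C(=O)/C=C/c2cc(Cl)ccc2O)c2c1C=CC(C)(C)O2` differs from compound 2 in one place: 5-chloro-2-hydroxyphenyl in place of 3,4-dichlorophenyl on a double-bonded chain carbon bound to a double-bonded chain carbon. Among the measured compounds shown here, the single measured step also exchanged the aromatic ring at this very place and produced no change beyond the scatter. For the measured compounds named here, no measured compound carries a hydroxyl on that ring, so the new hydrogen-bond donor has no precedent here. Going by the values given here, with only one step, and that one within the scatter, the expectation for compound 3 in this assay is a small step, a 1.3-fold lower number from compound 2 to compound 3 (0.11 log units; within the scatter), and a wide range. The estimate for compound 3 is 6000 nM, between 2000 nM and 18000 nM.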

Compound 3, half-maximal inhibitory concentration: 4230 nM
Estimate against measurement, compound 3: 1.4-fold (0.15 log units) above; low and high end bracket the measured number.
By their numbers in this assay, from the lowest: compounds 1, 3 and 2 (each within the scatter of the next).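

In this assay the ring on a double-bonded chain carbon bound to a double-bonded chain carbon has now been varied three ways, and bringing in 5-chloro-2-hydroxyphenyl gives a 1.8-fold lower number from compound 2 to compound 3 (0.26 log units; within the scatter) and also a 1.0-fold higher number from compound 1 to compound 3 (0.01 log units; within the scatter) as its two steps. The hydrogen-bond donor that enters with this ring therefore produces no change that can be told from the scatter, and compounds 1, 2 and 3 cannot be ranked against one another. Nothing available here offers an explanation for how closely these three rings read.

Going by these compounds, what a ring bearing an amine or a carboxylic acid would give at this place stays open, as does a ring with a hydroxyl and no chlorine. Also open, on these data alone, is whether any change at this place can move the number beyond the scatter.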